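Removing the Nitro Group: Expected Loss of Potency

The compounds below may be only part of what the source reports. "The series", "measured", "known", "first", "only" and "open" are said of these compounds alone.

For the measured compounds named here, compound 2 `O=C(OC1(C(=O)Nc2ccc([N+](=O)[O-])cc2)CCCCC1)c1ccc([N+](=O)[O-])cc1` gives 8.7 nM in a functional assay on MCF7 cells (Homo sapiens) for inhibition, read by MTT assay, with a stated time of 72 h (a lower number here means a stronger inhibitor, a higher number a weaker inhibitor), the lowest of the two numbers measured so far, while compound 1 `O=C(OC1(C(=O)Nc2ccc([N+](=O)[O-])cc2)CCCCC1)c1ccc(Br)cc1` gives 237 nM. Compound 3 `O=C(OC1(C(=O)Nc2ccc([N+](=O)[O-])cc2)CCCCC1)c1ccccc1` differs from compound 2 by a single change: hydrogen in place of nitro on an aromatic carbon Cut one bond further out, the same difference reads 4-nitrophenyl to phenyl. Going by the values given here, the only measured step that bears on it is a 27-fold lower number from compound 1 to compound 2 (1.44 log units; beyond the scatter), a large gain from bringing nitro in. Taking nitro away again is expected to move the number back up, by a step of about a 34-fold higher number from compound 2 to compound 3 (1.54 log units; beyond the scatter). Compound 3 is therefore estimated at 300 nM, within a range of 60 nM to 1500 nM.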

Compound 3, half-maximal inhibitory concentration: 903 nM
Beside the measured number, compound 3's estimate is 3.0-fold (0.48 log units) below it; the range from low to high includes it.
By their numbers in this assay, from the lowest: compound 2; then compound 1; then compound 3.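

Going from nitro to plain hydrogen at this position is a far larger change than the swap from bromo to nitro suggested: the step is a 100-fold higher number from compound 2 to compound 3 (2.02 log units; beyond the scatter) in this assay. Bromo also counts for something, since removing it gives a 3.8-fold higher number from compound 1 to compound 3 (0.58 log units; beyond the scatter), a modest step, so the numbers rise from nitro through bromo to hydrogen. Most of the potency of compound 2 is therefore tied to nitro itself, not merely to having any group there. From the compounds shown here alone, whether an amine or a nitrile at this position would come close to nitro remains open. Nothing available explains why these three compounds differ so much.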